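Carboxy replaces methylaminomethyl on the isoxazole arm

A few compounds are considered here, and "the series" means these few. Any claim that something is new, unique, unknown or untested is made for them only; others in the source may bear on it.

Measured compounds:
- compound 1, `CCNC(=O)c1noc(-c2cc(C(C)C)c(O)cc2O)c1-c1cc(CNC)no1`: "not determined" (no result reported)
- compound 2, `CCNC(=O)c1noc(-c2cc(C(C)C)c(O)cc2O)c1-c1cc(CN2CCCC2)no1`: 55 nM
- compound 3, `CCNC(=O)c1noc(-c2cc(C(C)C)c(O)cc2O)c1-c1cc(C(=O)OCC)no1`: 9000 nM

In a functional assay on A2780 cells (Homo sapiens) for inhibition (on this read-out lower numbers stand for stronger inhibition and higher numbers for weaker inhibition), compound 1 gives "not determined" (no result reported), so it has no single number to stand on. Its neighbours on the shared core do: in this assay compound 2 gives 55 nM, while compound 3 gives 9000 nM.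

The new compound is compound 4, `CCNC(=O)c1noc(-c2cc(C(C)C)c(O)cc2O)c1-c1cc(C(=O)O)no1`. It differs from compound 1 in one place: carboxy in place of (methylamino)methyl on an aromatic carbon.

Within the data shown here, the only measured step that bears on this change is the one on the same aromatic carbon, where a group with a basic nitrogen gives way to a carbonyl-bearing group: a 160-fold higher number from compound 2 to compound 3 (2.21 log units; beyond the scatter). The change from compound 1 to compound 4 also replaces an amine-bearing group with a carbonyl-bearing group, the carboxy, on that carbon. A step of comparable direction, towards a higher number in this assay, is therefore expected here, though compound 1 itself offers no value to measure it against.

Compound 4 is accordingly expected to give an estimated 12000 nM in this assay, in a range from 2500 nM to 60000 nM.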

Compound 4, half-maximal inhibitory concentration: 20000 nM
Compound 4: the middle estimate sits 1.7-fold (0.22 log units) below what was measured; low and high end bracket the measured number.
By their numbers in this assay, from the lowest: compound 2; then compound 3; then compound 4.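

In this assay, the carboxy group on this aromatic carbon gives a still higher number than the ethoxycarbonyl group, with a 2.2-fold higher number from compound 3 to compound 4 (0.35 log units; beyond the scatter), so replacing the ethyl on that oxygen with hydrogen recovers no inhibition. Set against the (pyrrolidin-1-yl)methyl group, the carboxy group gives a 360-fold higher number from compound 2 to compound 4 (2.56 log units; beyond the scatter), and most of that distance is already covered by a 160-fold higher number from compound 2 to compound 3 (2.21 log units; beyond the scatter); both carbonyl-bearing groups thus stand far above the amine-bearing compound 2, while still differing from each other beyond the scatter. Nothing shown gives a reason for this order among the three groups.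

Steps from compound 1 cannot be read, so it stays open whether the (methylamino)methyl group would stand near the (pyrrolidin-1-yl)methyl group of compound 2 or apart from it. Also open, going by these compounds, is where a primary carboxamide, a hydroxymethyl group or a longer aminoalkyl chain on this carbon would fall relative to compound 2 and compound 4, and so whether the high numbers belong to carbonyl-bearing groups in general or only to the two seen here.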